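The compounds below may be only part of what the source reports. "The series", "measured", "known", "first", "only" and "open" are said of these compounds alone.

Compound 1 `Fc1ccc(-c2cn3nc(Cc4ccc(Cl)cc4)sc3n2)cc1`: in a functional assay on L1210 cells (Mus musculus) for cytotoxicity, with a stated time of 48 h (on this read-out higher numbers stand for weaker inhibition and lower numbers for stronger inhibition), compound 1 gives > 250000 nM, a limit of the assay.
Compound 2 `Clc1ccc(Cc2nn3cc(-c4ccc(Br)cc4)nc3s2)cc1`: in this assay compound 2 gives > 250000 nM, a limit of the assay.
Compound 3 `Clc1ccc(Cc2nn3c(Br)c(-c4ccc(Br)cc4)nc3s2)cc1`: in this assay compound 3 gives > 250000 nM, a limit of the assay.

All three measured compounds sit at the same limit, (the limit of > 250000 nM in this assay, at which 3 of the 3 values shown sit). Two single-point changes connect them: the step that the two limits leave unreadable from compound 1 to compound 2 and the step that the two limits leave unreadable from compound 2 to compound 3. Neither step can be sized, since a limit stands at both ends of each. Compound 3 therefore stands only at the limit, and nothing in these numbers sets it apart from compound 1 or compound 2.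

The unmeasured compound 4 `Clc1ccc(Cc2nn3c(Br)c(-c4ccc(Cl)cc4Cl)nc3s2)cc1` is reached from compound 3 by one change, (2,4-dichlorophenyl in place of 4-bromophenyl on an aromatic carbon). Going by the values given here, the steps that bear on it, a step that the two limits leave unreadable from compound 1 to compound 2 and a step that the two limits leave unreadable from compound 2 to compound 3, are both unreadable, and they concern the same phenyl ring and its neighbouring position. With three compounds all at the limit, no step beyond the scatter is expected in this assay in either direction for this change. Compound 4 is therefore expected to remain at the limit and is estimated at 250000 nM, with a range from 100000 nM to 1000000 nM. This estimate means an expected step of a number no higher from compound 3 to compound 4 (the limit leaves the size open), within the scatter.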

Compound 4, half-maximal inhibitory concentration: 31000 nM
For compound 4 the middle estimate is 8.1-fold (0.91 log units) above the measured one; the whole stated range lies above it.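

In this assay, going by these compounds alone, the replacement of 4-bromophenyl by 2,4-dichlorophenyl on this aromatic carbon gives an at least 8.0-fold lower number from compound 3 to compound 4 (0.90 log units; beyond the scatter) and so yields the first step that can be sized, while the earlier steps cannot be read. Within the data shown here, it shows that a change at this place on the shared core can bring a compound off the limit, something the earlier compounds could not show, since each of them sat at that limit, and the same holds for the one end of this step: the limit of > 250000 nM in this assay, at which 3 of the 4 values shown sit. On these data alone, for compound 3 the value > 250000 nM is a limit of the assay, so the true size of the step stays open and only its lower bound is known.

The change removes one halogen and brings in two, so the compounds shown leave open whether the 2-chloro group, the 4-chloro group or the pair accounts for the step, and whether it would persist without the bromo group on the neighbouring ring atom. They also leave open how a phenyl ring carrying an amine, a methoxy group or a carboxylic acid would read at this place.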